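Acyl Group Swap on a Shared Core in the Writhing Test

This account rests on a few compounds, and the source may have more. Where it says the series, first, only, none or still open, it means among the compounds named here.

Three compounds built on one shared core have been measured in a functional assay on the whole organism (strain CF-1) with Mus musculus as the target, in the writhing test, with a stated time of 15 min; on this read-out lower numbers stand for an effect already at smaller amounts and higher numbers for an effect only at larger amounts of compound:

compound 1, `c1ccc(CNC2=NC3(CCCCO3)CCS2)cc1`: > 200 mg/kg
compound 2, `S=C(/N=C1\NC2(CCCCO2)CCS1)Nc1ccccc1`: 200 mg/kg
compound 3, `O=C(/N=C1\NC2(CCCCO2)CCS1)c1ccccc1`: 5 mg/kg

Compound 3 stands lowest of the two numbers that were obtained. Its nearest neighbour, compound 2, sits at a far higher number, a gap that lies beyond the scatter. Compound 1 is reported only as a limit, (the limit of > 200 mg/kg in this assay, at which 1 of the 3 values shown sits), and not as a number.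

Compound 4, `CC1(C(=O)/N=C2\NC3(CCCCO3)CCS2)CCCCC1`, has not yet been measured in this assay. It differs from compound 3 in one place: 1-methylcyclohexyl in place of phenyl on a carbonyl carbon. Both groups sit on the same carbonyl carbon, and the rest of the core is unchanged. Going by the values given here, no measured pair shows a step of this kind, so the expectation rests on compound 3 alone. The step of a 2.0-fold higher number from compound 3 to compound 4 (0.30 log units; within the scatter) is expected to be modest, toward a somewhat higher number, and may well fall within the scatter. Compound 4 is accordingly estimated at about 10 mg/kg, in a range from 3 mg/kg to 40 mg/kg.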

Compound 4, dose for half-maximal effect: > 200 mg/kg
Compound 4: only a limit was reported (the forecaster's own chance of this, stated with the estimate: 10%); at least 20-fold (1.30 log units) between middle value and limit.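

At the carbonyl carbon, 1-methylcyclohexyl in place of phenyl gives an at least 40-fold higher number from compound 3 to compound 4 (1.60 log units; beyond the scatter) in this assay. With the rest of the core unchanged, this shows that the group at this place can decide the read-out, and that a six-membered ring of carbon alone does not carry the effect seen for compound 3. Compound 4 is reported only as a limit and not as a number: the limit of > 200 mg/kg in this assay, at which 2 of the 4 values shown sit.

This single step changes the aromatic ring and adds the methyl group together, so it cannot tell which of the two matters, and nothing shown gives a cause. It also leaves open whether plain cyclohexyl, or a phenyl ring carrying a methoxy group or a chlorine atom, would stay close to compound 3.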